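Swapping methoxy for chloro: what compound 4 may do

This account rests on a few compounds, and the source may have more. Where it says the series, first, only, none or still open, it means among the compounds named here.

In a functional assay (aorta) for inhibition, with Rattus norvegicus as the target (a higher number here means a weaker inhibitor, a lower number a stronger inhibitor), compound 3 `COc1cccc(N2CCN(c3ccc(-c4nc(C)ns4)nn3)CC2)c1` gives 7 nM. Compound 2 `Cc1nsc(-c2ccc(N3CCN(c4cccc(F)c4)CC3)nn2)n1` gives 6 nM, and the gap between these two is small: a 1.2-fold higher number from compound 2 to compound 3 (0.07 log units; within the scatter). Compound 1 `Cc1nsc(-c2ccc(N3CCN(c4cccc(Cl)c4)CC3)nn2)n1` gives 0.6 nM, which makes it the strongest inhibitor of the three.

The next compound, compound 4 `Cc1nsc(-c2ccc(N3CCN(c4cc(Cl)cc(Cl)c4)CC3)nn2)n1`, carries 3,5-dichlorophenyl in place of 3-methoxyphenyl on an amine nitrogen in a ring.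

The closest guide is the swap between chloro and methoxy, here read in reverse: a 12-fold higher number from compound 1 to compound 3 (1.07 log units; beyond the scatter). The swap of chloro for fluoro points the same way: a 10-fold higher number from compound 1 to compound 2 (1.00 log units; beyond the scatter). Both suggest that chloro goes with a lower number in this assay. For the measured compounds named here, no measured step shows what further chloro does, so the range must stay wide. A large step towards a lower number is therefore expected, with the estimate being an 8.8-fold lower number from compound 3 to compound 4 (0.94 log units; beyond the scatter). Compound 4 is estimated at 0.8 nM, with an expected range from 0.15 nM to 5 nM.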

Compound 4, half-maximal inhibitory concentration: < 0.1 nM
Compound 4 ended at the assay's limit; the forecaster's own chance of this, stated with the estimate: 2%; at least 8.0-fold (0.90 log units) between middle value and limit.
By their numbers in this assay, from the lowest: compound 1; then compounds 2 and 3 (each within the scatter of the next). At a limit, below all of these: compound 4.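

A further chloro in place of hydrogen on an aromatic carbon lowers the number again (an at least 6.0-fold lower number from compound 1 to compound 4 (0.77 log units; beyond the scatter)), so at this position the benefit of chloro does not end with a single one. The 3,5-dichlorophenyl group also stands well apart from the two groups with no chloro, 3-methoxyphenyl (an at least 70-fold lower number from compound 3 to compound 4 (1.84 log units; beyond the scatter)) and 3-fluorophenyl (an at least 60-fold lower number from compound 2 to compound 4 (1.77 log units; beyond the scatter)), and none of the four compounds goes against this order. The reading for compound 4 in this assay is a limit and not a number: the limit of < 0.1 nM in this assay, at which 1 of the 4 values shown sits.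

As far as these compounds go, how far compound 4 really lies past that limit stays open, so the full size of these steps is unknown. Also open, from the compounds shown here alone, is whether bromo or trifluoromethyl on the same aromatic ring would match chloro, and whether a second fluoro or methoxy would lower the number as the further chloro does.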